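A few compounds are considered here, and "the series" means these few. Any claim that something is new, unique, unknown or untested is made for them only; others in the source may bear on it.

Measured compounds:
compound 1 `O=C(CI)NCCCCCCCCNc1ncnc2c1ncn2[C@@H]1O[C@H](COP(=O)(O)OP(=O)(O)OP(=O)(O)O)[C@@H](O)[C@H]1O`: 35% in an assay on isolated protein for inhibition of hexokinase-1 (Rattus norvegicus), with a stated time of 6 h, tested at 10 mM; on this read-out lower numbers stand for less inhibition and higher numbers for more inhibition at the one concentration tested (going by the name of the read-out)
compound 2 `Nc1ncnc2c1nc(NCCCCNC(=O)CI)n2[C@@H]1O[C@H](COP(=O)(O)OP(=O)(O)OP(=O)(O)O)[C@@H](O)[C@H]1O`: 0% in this assay
compound 3 `O=C(CI)NCCCCCC(=O)NCCCNc1ncnc2c1ncn2[C@@H]1O[C@H](COP(=O)(O)OP(=O)(O)OP(=O)(O)O)[C@@H](O)[C@H]1O`: 0% in this assay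

Among these three, compound 1 stands highest in this assay; compound 2 and compound 3 both sit a gap below it that lies beyond the usual scatter. Compound 4 `O=C(CI)NCCCCCCCNc1ncnc2c1ncn2[C@@H]1O[C@H](COP(=O)(O)OP(=O)(O)OP(=O)(O)O)[C@@H](O)[C@H]1O` has not yet been measured. It differs from compound 1 by ((iodomethyl)carbonyl)amino in place of (((iodomethyl)carbonyl)amino)methyl on a saturated chain carbon, seven bonds along the chain from a nitrogen on an aromatic ring.

For the measured compounds named here, no measured pair in this set shows a step of this kind, so there is no direct guide to its size. The chain is shortened by one carbon while the terminal group is kept, and such a step is expected to produce no change beyond the scatter in this assay, if anything a slight drop. Compound 4 is therefore expected to give about 28%, estimated to fall between 8% and 48%. The expected step of a number 7 percentage points lower from compound 1 to compound 4 (within the scatter) is estimated to stay within the scatter.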

Compound 4, a percentage reported as inhibition, at one concentration (the size of the read-out at that concentration, not a potency): 20%
Estimate against measurement, compound 4: 8 percentage points above; low and high end bracket the measured number.
By their numbers in this assay, from the lowest: compounds 2 and 3 (each within the scatter of the next); then compound 4; then compound 1.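

In this assay, removing one methylene unit from the chain while keeping the terminal ((iodomethyl)carbonyl)amino group gives a number 15 percentage points lower from compound 1 to compound 4 (beyond the scatter). For the compounds shown here, this is the first single-place comparison in the set, and it shows that this position responds to a one-carbon change in chain length, although compound 4 still gives 20%. No available evidence accounts for the size of this step. The compounds shown leave open whether a longer chain than in compound 1 would raise the inhibition further or lower it. They also leave open how a bromine in place of the terminal iodine would read at this chain length.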